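The compounds below may be only part of what the source reports. "The series", "measured", "known", "first", "only" and "open" are said of these compounds alone.

Working notes on the series, all read in a functional assay on NCI/ADR-RES cells (Homo sapiens) for antiproliferative activity, read by sulforhodamine B assay, with a stated time of 48 h; a higher number here means a weaker inhibitor of growth, a lower number a stronger inhibitor of growth. Compound 1 (`CCCCCCCCCCCCCCCCCC(=O)N1CCOCC1`) gives 33.1 ug/mL and compound 3 (`CCCCCCCCCCCCCCCCCC(=O)N[C@H](C)c1ccccc1`) gives 25.7 ug/mL. Compound 2 (`CCCCCCCC/C=C\CCCCCCCC(=O)N1CCCC1`) gives 0.2 ug/mL, the lowest of the three numbers and beyond the scatter from both of the others.

Compound 4 (`CCCCCCCC/C=C\CCCCCCCC(=O)N1CCCCC1`) differs from compound 2 in one place, with piperidin-1-yl in place of pyrrolidin-1-yl on a carbonyl carbon.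

One measured step changes only the group on a carbonyl carbon: a 1.3-fold lower number from compound 1 to compound 3 (0.11 log units; within the scatter), with (1-phenylethyl)amino in place of morpholin-4-yl, which lies within the scatter. That step sits on the saturated chain and involves other groups, so it is only a weak guide here. Compound 2 differs from the other two measured compounds in both chain and amide group, and the data do not divide its gap between these two changes. For the measured compounds named here, no measured pair isolates the pyrrolidin-1-yl group on the unsaturated chain.

The expected step in this assay is small and upward, a 2.0-fold higher number from compound 2 to compound 4 (0.30 log units; within the scatter), with more room on the high side than the low. For compound 4 the estimated value is 0.4 ug/mL, with an expected range of 0.1 ug/mL to 4 ug/mL.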

Compound 4, concentration for 50% growth inhibition: 7.7 ug/mL
Compound 4: middle estimate off by 19-fold (1.28 log units), on the low side; the measured number lies above the stated range.
By their numbers in this assay, from the lowest: compound 2; then compound 4; then compounds 3 and 1 (each within the scatter of the next).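

In this assay, the change on the carbonyl carbon of the unsaturated chain gives a large step: a 39-fold higher number from compound 2 to compound 4 (1.59 log units; beyond the scatter), with piperidin-1-yl in place of pyrrolidin-1-yl. For the compounds shown here, this is the first reading of the amide group with the unsaturated chain held fixed, and it shows that going from a five-membered to a six-membered non-aromatic ring is enough to separate two compounds well beyond the scatter, whereas the only earlier step at a carbonyl carbon, a 1.3-fold lower number from compound 1 to compound 3 (0.11 log units; within the scatter), was on the saturated chain and with other groups, and did not separate its pair. Nothing in the data on hand accounts for the size of the step.

The compounds shown leave open whether the preference for pyrrolidin-1-yl over piperidin-1-yl also holds on the saturated chain, since neither group appears there, and how much of the gap between compound 2 and the saturated compounds belongs to the chain. They also leave open how the series continues on the unsaturated chain with a seven-membered azepan-1-yl ring or an open dimethylamino group on the same carbonyl carbon.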